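The compounds below may be only part of what the source reports. "The series", "measured", "known", "first", "only" and "open" are said of these compounds alone.

Compound 1 `CC(C)=CCc1cc(C(=O)Nc2cc3ccc(OCC4CCCN(C)C4)c(C)c3oc2=O)ccc1O` gives 2640 nM in a functional assay on MCF7 cells (Homo sapiens) for antiproliferative activity; on this read-out lower numbers stand for stronger inhibition and higher numbers for weaker inhibition.
Compound 2 `CCN(C)CCCOc1ccc2cc(NC(=O)c3ccc(O)c(CC=C(C)C)c3)c(=O)oc2c1C` gives 2190 nM.
Compound 3 `CC(C)=CCc1cc(C(=O)Nc2cc3ccc(OCCCN(C)C4CCCCC4)c(C)c3oc2=O)ccc1O` gives 1080 nM.

Of these three numbers compound 2 stands second highest. The step of a 1.2-fold lower number from compound 1 to compound 2 (0.08 log units; within the scatter) lies within the scatter, whereas a 2.0-fold lower number from compound 2 to compound 3 (0.31 log units; beyond the scatter) is a modest step beyond it.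

Compound 4 `CC(C)=CCc1cc(C(=O)Nc2cc3ccc(OCCCNc4ccccc4)c(C)c3oc2=O)ccc1O` has not yet been measured in this assay. It differs from compound 2 in one place: anilino in place of ethyl(methyl)amino on a saturated chain carbon, three bonds along the chain from an oxygen on an aromatic ring.

The measured steps that bear on this change are those at the same chain carbon, a 2.0-fold lower number from compound 2 to compound 3 (0.31 log units; beyond the scatter) and a 2.4-fold lower number from compound 1 to compound 3 (0.39 log units; beyond the scatter), both modest, together with a 1.2-fold lower number from compound 1 to compound 2 (0.08 log units; within the scatter), which stayed within the scatter. Within the data shown here, both modest steps ran toward lower numbers when a bigger group was placed on the amine nitrogen, and anilino is again the bigger group here; no measured step, however, exchanges a dialkylamino group for an anilino group. A small step toward a lower number, or none beyond the scatter, is therefore expected, namely a 1.5-fold lower number from compound 2 to compound 4 (0.16 log units; within the scatter). Compound 4 is estimated at 1500 nM, with a range from 500 nM to 4500 nM.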

Compound 4, half-maximal inhibitory concentration: > 50000 nM
Compound 4 gave a limit, no number; the forecaster's own chance of this, stated with the estimate: 5%; middle value at least 33-fold (1.52 log units) from the limit.
By their numbers in this assay, from the lowest: compound 3; then compounds 2 and 1 (each within the scatter of the next). At a limit, above all of these: compound 4.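

Compound 4 gave a limit of the assay, not a number: the limit of > 50000 nM in this assay, at which 1 of the 4 values shown sits. At this saturated chain carbon, the earlier changes of amine had produced modest steps at most, whereas anilino gives an at least 22-fold higher number from compound 2 to compound 4 (1.35 log units; beyond the scatter), an at least 46-fold higher number from compound 3 to compound 4 (1.66 log units; beyond the scatter) and an at least 18-fold higher number from compound 1 to compound 4 (1.27 log units; beyond the scatter), so in this assay this position does not accept every group that ends in an amine nitrogen. A larger group or a six-membered ring on that nitrogen does not by itself account for the rise, as compound 3 goes against that reading: it carries the cyclohexyl ring and has the lowest number of the series.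

The compounds shown leave open whether the rise goes with the aromatic ring of anilino or with its hydrogen-bond donor. Methyl(phenyl)amino and cyclohexylamino on the same chain carbon would separate these two features.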